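The compounds below may be only part of what the source reports. "The series", "measured", "known", "first", "only" and "open" are said of these compounds alone.

Measured compounds in a functional assay on HepG2 cells (Homo sapiens) for cytotoxicity, read by MTT assay, with a stated time of 48 h; on this read-out higher numbers stand for weaker inhibition and lower numbers for stronger inhibition:
compound 1, `CCCCCCCCCCCCNC(=O)[C@@H](NC(=O)c1cc2ccccc2[nH]1)[C@@H](C)O`: 12000 nM
compound 2, `C/C=C/C=C/C(=O)N[C@H](C(=O)NCCCCCCCCCCCC)[C@@H](C)O`: > 400000 nM, which is a limit of the assay and not a number
compound 3, `CCCCCCCCCCCCNC(=O)[C@@H](NS(=O)(=O)c1cccs1)[C@@H](C)O`: 25900 nM

Compound 2 sits at the limit of > 400000 nM in this assay, at which 1 of the 3 values shown sits, so on this assay compound 2 is placed only by its limit and stands above both numbered values. The two measured steps both change the group on the amine nitrogen: an at least 33-fold higher number from compound 1 to compound 2 (1.52 log units; beyond the scatter) and an at least 15-fold lower number from compound 2 to compound 3 (1.18 log units; beyond the scatter). Compound 4, `C/C=C/C=C/C(=O)N[C@H](C(=O)NCCCCCCCCCCCCCC)[C@@H](C)O`, keeps the acyl group of compound 2 unchanged and differs from it only at the far end of the chain: ethyl in place of hydrogen on a saturated chain carbon, ten or more bonds along the chain from an amide-type nitrogen. For the measured compounds named here, no measured step touches the chain, so neither of the two measured steps bears on this change, and there is no ground to expect a step beyond the scatter in this assay. The expected step is a number no higher from compound 2 to compound 4 (the limit leaves the size open), meaning no change beyond the scatter. Compound 4 is therefore estimated at about 400000 nM, with a range from 150000 nM to 1000000 nM, and most likely it will again be reported only as a limit.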

Compound 4, half-maximal inhibitory concentration: > 400000 nM
Compound 4: only a limit was reported (the forecaster's own chance of this, stated with the estimate: 80%); the middle value sits exactly at the limit.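

Compound 2 and compound 4 are both held only by limits of the assay, so no step can be read between them: the limit of > 400000 nM in this assay, at which 2 of the 4 values shown sit.

Still open, from the compounds shown here alone, is whether ethyl in place of hydrogen on the chain changes the number in compound 1 or compound 3, which carry measured values rather than limits.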